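Swapping the Side Ring: Compound 4 Before Measurement

A few compounds are considered here, and "the series" means these few. Any claim that something is new, unique, unknown or untested is made for them only; others in the source may bear on it.

Three compounds have been measured in a functional assay on SiHa cells (Homo sapiens) for antiproliferative activity, read by CCK-8 assay, with a stated time of 72 h; a lower number here means a stronger inhibitor, a higher number a weaker inhibitor:

Compound 1 `COc1ccc(-c2cncnc2-c2cc(OC)c(OC)c(OC)c2)cc1F` gives 3340 nM
Compound 2 `COc1cc(-c2ncncc2-c2ccc(SC)cc2)cc(OC)c1OC` gives 560 nM
Compound 3 `COc1ccc(-c2cncnc2-c2cc(OC)c(OC)c(OC)c2)nc1` gives 1750 nM

Compound 1 stands at the highest of the three numbers. The step of a 1.9-fold lower number from compound 1 to compound 3 (0.28 log units; within the scatter) stays small, whereas a 6.0-fold lower number from compound 1 to compound 2 (0.78 log units; beyond the scatter) is a clear, modest move to a lower number, and a 3.1-fold higher number from compound 2 to compound 3 (0.49 log units; beyond the scatter) runs the other way.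

Compound 4 `COc1cc(-c2ncncc2-c2ccc(Br)cc2)cc(OC)c1OC` differs from compound 1 in one place: 4-bromophenyl in place of 3-fluoro-4-methoxyphenyl on an aromatic carbon. Among the compounds with values here, the step that bears most on this change is the one to compound 2, where a different single-substituent phenyl ring replaced the same 3-fluoro-4-methoxyphenyl group and lowered the number by a modest amount. On that basis compound 4 is expected to give a lower number than compound 1, though the evidence from one step is thin. The estimate for compound 4 is 1100 nM, with a range from 350 nM to 3500 nM. This estimate corresponds to an expected step of a 3.0-fold lower number from compound 1 to compound 4 (0.48 log units; beyond the scatter).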

Compound 4, half-maximal inhibitory concentration: 2960 nM
Compound 4: middle estimate off by 2.7-fold (0.43 log units), on the low side; low and high end bracket the measured number.
By their numbers in this assay, from the lowest: compound 2; then compounds 3, 4 and 1 (each within the scatter of the next).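

In this assay, the 4-bromophenyl ring does not repeat what the 4-(methylsulfanyl)phenyl ring did: a 1.1-fold lower number from compound 1 to compound 4 (0.05 log units; within the scatter) is a step too small to read as a change, and a 1.7-fold higher number from compound 3 to compound 4 (0.23 log units; within the scatter) is equally small. The telling comparison is a 5.3-fold higher number from compound 2 to compound 4 (0.72 log units; beyond the scatter), where only bromo replaces methylsulfanyl, so a phenyl ring with one substituent is not enough to give the lower number, and the identity of that substituent matters here. Nothing measured here explains why these two substituents give such different numbers.

The compounds shown leave open whether the lower number is special to methylsulfanyl or would also appear with a longer chain such as ethylsulfanyl. They also leave open what an amine or a carboxylic acid on this phenyl ring would give.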